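This account rests on a few compounds, and the source may have more. Where it says the series, first, only, none or still open, it means among the compounds named here.

Measured so far in a physicochemical assay for lipophilicity, read by HPLC, measured as chromatographic lipophilicity, at pH 7.4; a higher number here means a more lipophilic compound, a lower number a more polar compound:
compound 1 `Cc1nnc(N2CCC(C(=O)N3N=CC[C@H]3c3cc(F)cc(F)c3)CC2)o1`: 3.6
compound 2 `CC1=NN(C(=O)C(C)(C)C)[C@H](c2ccccc2)C1`: 6.4
compound 3 `Cc1nnc(N2CCC(C(=O)N3N=CC[C@H]3c3ccccc3)CC2)o1`: 3.2

Compound 1 stands second highest of the three numbers in this assay. Its nearest neighbour is compound 3, with a number 0.40 log units lower from compound 1 to compound 3 (beyond the scatter), a change of the phenyl in place of 3,5-difluorophenyl on a saturated ring carbon. Among the measured compounds shown here, compound 2 lies furthest away, its value in this assay well above that of compound 1, but compound 2 shares little of the structure of compound 1 and no single-point step connects the two.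

Compound 4 `N#Cc1nccc(N2CCC(C(=O)N3N=CC[C@H]3c3cc(F)cc(F)c3)CC2)n1` is not yet measured. It differs from compound 1 in one place: 2-cyanopyrimidin-4-yl in place of 5-methyl-1,3,4-oxadiazol-2-yl on an amine nitrogen in a ring. For the measured compounds named here, none of the measured steps touches this ring nitrogen or these two groups; the only measured step, from compound 1 to compound 3, concerns the aryl group on the saturated ring carbon and is modest. Going by the values given here, there is thus no measured precedent, and the expectation rests only on the counted difference: the group that enters carries more heavy atoms than the one that leaves, with donors, acceptors and charge unchanged. A modest upward step beyond the scatter is therefore expected, a number 0.40 log units higher from compound 1 to compound 4 (beyond the scatter). For compound 4 the estimated value in this assay is 4, within a range of 3.5 to 4.5.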

Compound 4, distribution coefficient: 5.1
Compound 4: the middle estimate sits 1.10 log units below what was measured; measured number above the stated range.
By their numbers in this assay, from the lowest: compound 3; then compound 1; then compound 4; then compound 2.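

In this assay, among the compounds shown here, the amine nitrogen in the six-membered non-aromatic ring proves to be a place where one change moves the number far, a number 1.50 log units higher from compound 1 to compound 4 (beyond the scatter), whereas the only earlier step, on the saturated ring carbon at the other end of the molecule, was printed as modest: a number 0.40 log units lower from compound 1 to compound 3 (beyond the scatter). The counts show that this large step comes with no difference in hydrogen-bond donors, hydrogen-bond acceptors or net charge, so those counts alone do not track the size of the change here; what differs is the ring type, the heavy-atom make-up and the triple bond of the nitrile in 2-cyanopyrimidin-4-yl. No measurement on hand accounts for the size of this step.

The swap of 5-methyl-1,3,4-oxadiazol-2-yl for 2-cyanopyrimidin-4-yl changes the ring and the nitrile together, so their shares stay unresolved, and a plain pyrimidin-4-yl or a 2-aminopyrimidin-4-yl on the same nitrogen would separate them. Also open, as far as these compounds go, is whether a step of this size holds with phenyl in place of 3,5-difluorophenyl on the saturated ring carbon.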